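The source may report more compounds than this note shows. Statements on the series, on what has been measured and on what is new or still open speak of the compounds shown alone.

Measured so far in an in vivo ADME assay on the whole organism (strain Mongrel) for metabolic stability, with Canis familiaris (Canis lupus familiaris) as the target; on this read-out lower numbers stand for a shorter-lived compound and higher numbers for a longer-lived compound:
Compound 1 `C[C@@H](NC(=O)C1(NC(=O)c2cncc(Cl)n2)CC1)c1ccc(-n2nc(Cl)c3ccccc32)cc1F`: 15.1 h
Compound 2 `C[C@@H](NC(=O)C1(NC(=O)c2cncc(Br)c2)CC1)c1ccc(-n2nc(Cl)c3ccccc32)cc1F`: 7.6 h

Within the data shown here, compound 2 stands lowest of the two numbers, though the only measured step, a 2.0-fold lower number from compound 1 to compound 2 (0.30 log units; within the scatter), lies within the scatter. Compound 3 `Cc1cncc(C(=O)NC2(C(=O)N[C@H](C)c3ccc(-n4nc(Cl)c5ccccc54)cc3F)CC2)c1` differs from compound 2 by methyl in place of bromo on an aromatic carbon. Among the measured compounds shown here, that single measured step swaps one whole ring for another and leaves the bromo group untouched, so no measured step bears directly on this change. With nothing pointing either way, no step beyond the scatter is expected in this assay. The estimate for compound 3 is 7.5 h, with a range of 3 h to 19 h, meaning an expected step of a 1.0-fold lower number from compound 2 to compound 3 (0.01 log units; within the scatter).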

Compound 3, half-life: 2.6 h
Compound 3: the middle estimate sits 2.9-fold (0.46 log units) above what was measured; the measured number lies below the stated range.
By their numbers in this assay, from the lowest: compound 3; then compounds 2 and 1 (each within the scatter of the next).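

In this assay, the group on this aromatic carbon of the pyridine ring clearly counts: methyl in place of bromo, a swap of one heavy atom for another, gives a 2.9-fold lower number from compound 2 to compound 3 (0.47 log units; beyond the scatter) and so clears the scatter, which the earlier ring change did not. The larger ring change now also reads clearly, as a 5.8-fold lower number from compound 1 to compound 3 (0.76 log units; beyond the scatter) and is thus a real shortening of half-life. Nothing measured here explains these shifts. From the compounds shown here alone, how chloro, trifluoromethyl or methoxy on the same carbon would compare with bromo and methyl remains open.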